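One Ring Swapped: From Compound 3 to Compound 4

A few compounds are considered here, and "the series" means these few. Any claim that something is new, unique, unknown or untested is made for them only; others in the source may bear on it.

Compound 1 `Cc1ccc(N/C(S)=N/[C@H](C)c2cccc3ccccc23)nc1` gives 5 nM in a functional assay on RBL-2H3 cells (Rattus norvegicus) for inhibition; a lower number here means a stronger inhibitor, a higher number a weaker inhibitor.
Compound 2 `C[C@@H](/N=C(\S)Nc1ccccn1)c1cccc2ccccc12` gives > 100000 nM in this assay, which is a limit of the assay and not a number.
Compound 3 `C[C@@H](/N=C(\S)Nc1nccs1)c1cccc2ccccc12` gives > 100000 nM in this assay, again a limit rather than a number.

Going by these compounds, compound 3 therefore stands at the limit of > 100000 nM in this assay, at which 2 of the 3 values shown sit, so its true number is unknown. Compound 4 `Cc1cc(C)nc(N/C(S)=N/[C@H](C)c2cccc3ccccc23)c1` differs from compound 3 in one place: 4,6-dimethylpyridin-2-yl in place of 1,3-thiazol-2-yl on an amine nitrogen. Going by the values given here, two measured steps bear on this. The step of an at least 20000-fold higher number from compound 1 to compound 3 (4.30 log units; beyond the scatter) runs the opposite way to the change in hand, from a methylated pyridin-2-yl to the 1,3-thiazol-2-yl. The step of an at least 20000-fold higher number from compound 1 to compound 2 (4.30 log units; beyond the scatter) shows that removing a single methyl from the pyridin-2-yl also costs a great deal. The step that the two limits leave unreadable from compound 2 to compound 3 gives no readable size. Reversing the loss seen in compound 1 to compound 3, and adding a second methyl, a large drop in the number is expected. Compound 4 is expected to give 10 nM, within a range of 2 nM to 300 nM. This expectation amounts to an at least 10000-fold lower number from compound 3 to compound 4 (4.00 log units; beyond the scatter).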

Compound 4, half-maximal inhibitory concentration: > 100000 nM
Compound 4 gave a limit, no number; the forecaster's own chance of this, stated with the estimate: 10%; middle value at least 10000-fold (4.00 log units) away from the limit.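

Compound 4 keeps a methylated pyridin-2-yl on the amine nitrogen, yet exchanging the 5-methylpyridin-2-yl of compound 1 for its 4,6-dimethylpyridin-2-yl gives an at least 20000-fold higher number from compound 1 to compound 4 (4.30 log units; beyond the scatter). Methyl groups on the pyridin-2-yl are therefore not enough in themselves: among the compounds shown, only the 5-methylpyridin-2-yl of compound 1 gives a number rather than a limit, and the 4,6-dimethylpyridin-2-yl does not share that result. The steps to compound 4 from compound 2 and from compound 3 cannot be read, since both ends of each are limits: the limit of > 100000 nM in this assay, at which 3 of the 4 values shown sit.

Going by these compounds, how weak compound 2, compound 3 and compound 4 truly are stays unknown, so they cannot be ranked against one another. Also open, on these data alone, is whether an ethyl or a methoxy group could take the place of the methyl in compound 1.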